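Anilino substituent variation on a trimethoxystyryl sulfone core

A few compounds are considered here, and "the series" means these few. Any claim that something is new, unique, unknown or untested is made for them only; others in the source may bear on it.

Measured compounds:
compound 1 `COC(=O)CCNc1cc(CS(=O)(=O)/C=C/c2c(OC)cc(OC)cc2OC)ccc1OC` gives 1500 nM
compound 2 `COC(=O)C(C)(C)Nc1cc(CS(=O)(=O)/C=C/c2c(OC)cc(OC)cc2OC)ccc1OC` gives 2500 nM
compound 3 `COC(=O)C(Nc1cc(CS(=O)(=O)/C=C/c2c(OC)cc(OC)cc2OC)ccc1OC)c1ccc(F)cc1` gives 300 nM

In a functional assay on DU-145 cells (Homo sapiens) for cytotoxicity, read by trypan blue exclusion, with a stated time of 96 h (on this read-out higher numbers stand for weaker inhibition and lower numbers for stronger inhibition), compound 3 stands lowest of the three numbers. The two steps that reach it are a 5.0-fold lower number from compound 1 to compound 3 (0.70 log units; beyond the scatter) and an 8.3-fold lower number from compound 2 to compound 3 (0.92 log units; beyond the scatter), both beyond the scatter, whereas the step of a 1.7-fold higher number from compound 1 to compound 2 (0.22 log units; within the scatter) stays within it. So the only clear signal in the series is that the aryl-bearing group on the nitrogen is read as stronger than either of the two smaller ester-bearing groups.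

Compound 4 `COc1cc(OC)c(/C=C/S(=O)(=O)Cc2ccc(OC)c(NC(C(=O)O)c3ccc(Br)cc3)c2)c(OC)c1` keeps that arrangement and changes two things at once: (4-bromophenyl)(carboxy)methyl in place of (4-fluorophenyl)(methoxycarbonyl)methyl on a nitrogen on an aromatic ring. Within the data shown here, no measured step covers either the change of ester to acid or the change of halogen, so the measured steps bear on it only indirectly, by showing that the aryl-bearing group is retained. The expectation is therefore a step of no more than modest size, more likely toward a higher number, estimated as a 2.0-fold higher number from compound 3 to compound 4 (0.30 log units; within the scatter). Compound 4 is expected to give about 600 nM, with a range from 200 nM to 2000 nM.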

Compound 4, half-maximal inhibitory concentration: 300 nM
Compound 4: middle estimate off by 2.0-fold (0.30 log units), on the high side; the measured number falls inside the stated range.
By their numbers in this assay, from the lowest: compounds 3 and 4 (each within the scatter of the next); then compounds 1 and 2 (each within the scatter of the next).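

In this assay, the joint change on this nitrogen, carboxy for methoxycarbonyl and 4-bromophenyl for 4-fluorophenyl, can be made without a readable loss, with no change at the digits printed from compound 3 to compound 4 (within the scatter). The separation from the two smaller ester-bearing groups also survives this change, with a 5.0-fold lower number from compound 1 to compound 4 (0.70 log units; beyond the scatter) and an 8.3-fold lower number from compound 2 to compound 4 (0.92 log units; beyond the scatter), so the aryl-bearing signal now rests on two compounds and does not depend on keeping the methyl ester. No measured evidence offered here accounts for any of these steps.

Compound 4 carries both changes at once, so the separate contributions of the acid and the bromine cannot be read, and they may offset each other. Also open, going by these compounds, is how a plain phenyl or 4-chlorophenyl group on the same carbon, or a carboxamide in place of the carboxy group, would read.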